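Two Methoxy Groups on the Carbonyl-Bound Phenyl

A few compounds are considered here, and "the series" means these few. Any claim that something is new, unique, unknown or untested is made for them only; others in the source may bear on it.

Compound 1 `O=C(/C=C/c1cn(-c2ccccc2)nc1-c1ccsc1)c1ccccc1` was tested in a functional assay on Huh-7 cells (Homo sapiens) for inhibition, read by sulforhodamine B assay, with a stated time of 72 h (a lower number here means a stronger inhibitor, a higher number a weaker inhibitor), where compound 1 gives 4700 nM. Within the data shown here, of the two numbers known, this is the lower, yet compound 2 `COc1cc(OC)c(C(=O)/C=C/c2cn(-c3ccccc3)nc2-c2ccsc2)c(OC)c1`, which gives 6100 nM in this assay, lies within the scatter of it, so the two cannot be told apart. Compound 3 `COc1ccc(OC)c(C(=O)/C=C/c2cn(-c3ccccc3)nc2-c2ccsc2)c1` has not yet been measured; it differs from compound 1 by 2,5-dimethoxyphenyl in place of phenyl on a carbonyl carbon. Among the measured compounds shown here, no measured step for such a change exists, so the closeness of compound 1 and compound 2 is the only guide. The step of a 1.2-fold higher number from compound 1 to compound 3 (0.07 log units; within the scatter) is therefore expected to remain within the scatter, in either direction. For compound 3 the estimate is 5500 nM, with a range from 2500 nM to 12000 nM.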

Compound 3, half-maximal inhibitory concentration: 2100 nM
The estimate for compound 3 lay 2.6-fold (0.42 log units) above the measured number; measured number below the stated range.
By their numbers in this assay, from the lowest: compound 3; then compounds 1 and 2 (each within the scatter of the next).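

Among these compounds, putting 2,5-dimethoxyphenyl in place of phenyl on the carbonyl carbon gives a modest step (a 2.2-fold lower number from compound 1 to compound 3 (0.35 log units; beyond the scatter)) in this assay, the first change at this position that lies beyond the scatter. Compound 2 also carries methoxy groups on this ring, yet its number stays within the scatter of compound 1, so methoxy groups here do not lower the number in every arrangement. Nothing at hand gives a reason for this step. Still open, as far as these compounds go, is whether a single methoxy group would suffice, and whether a hydroxyl group, an amine or a carboxylic acid on this ring would give a lower or a higher number.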